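Chloro on the oxadiazole phenyl of compound 2

The compounds below may be only part of what the source reports. "The series", "measured", "known", "first", "only" and "open" are said of these compounds alone.

The three measured compounds share one core. Compound 1 `N=C(NO)NS(=O)(=O)c1cc(-c2nnc(-c3ccc(Cl)cc3)s2)c(Cl)cc1SCc1ccccc1` gives 2020 nM in a functional assay on UACC-62 cells (Homo sapiens); on this read-out higher numbers stand for weaker inhibition of growth and lower numbers for stronger inhibition of growth. Compound 2 `COc1cc(CSc2cc(Cl)c(-c3nc(-c4ccccc4)no3)cc2S(=O)(=O)NC(=N)NO)cc(OC)c1OC` gives 3090 nM, and compound 3 `N=C(NO)NS(=O)(=O)c1cc(-c2nc(-c3ccccc3)no2)c(Cl)cc1SCc1ccccc1` gives 1840 nM. Compound 2 carries the largest of the three numbers, but its gap to compound 1 and its gap to compound 3 both sit within the scatter, so the three cannot be told apart on this read-out. For the measured compounds named here, the one step between compounds that differ in a single place, a 1.7-fold lower number from compound 2 to compound 3 (0.23 log units; within the scatter), is likewise within the scatter.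

Compound 4 `COc1cc(CSc2cc(Cl)c(-c3nc(-c4ccc(Cl)cc4)no3)cc2S(=O)(=O)NC(=N)NO)cc(OC)c1OC` differs from compound 2 by chloro in place of hydrogen on an aromatic carbon. Going by the values given here, no measured pair isolates this change. Compounds 1 and 3 differ from each other both by the chloro on the phenyl and by the five-membered heterocycle, and their two values, given above, lie within the scatter of each other. The step from compound 2 to compound 3, which alters a different part of the molecule, also stayed within the scatter. On this basis the number for compound 4 is expected to stay close to that of compound 2, with a step of a 1.1-fold lower number from compound 2 to compound 4 (0.04 log units; within the scatter) not beyond the scatter. The estimate for compound 4 is 2800 nM, with a range from 1200 nM to 6500 nM.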

Compound 4, concentration for 50% growth inhibition: 1950 nM
Beside the measured number, compound 4's estimate is 1.4-fold (0.16 log units) above it, within the range that was stated.
By their numbers in this assay, from the lowest: compounds 3, 4, 1 and 2 (each within the scatter of the next).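

Compound 2 and compound 4 are the first pair shown to isolate chloro in place of hydrogen on an aromatic carbon, here the change from 3-phenyl-1,2,4-oxadiazol-5-yl to 3-(4-chlorophenyl)-1,2,4-oxadiazol-5-yl. In this assay this step (a 1.6-fold lower number from compound 2 to compound 4 (0.20 log units; within the scatter)) does not separate the two compounds, so on the 3,4,5-trimethoxyphenyl background a single chlorine at this place, para to a large group, leaves the read-out unresolved from the parent. The earlier compounds could only hint at this, as compound 1 and compound 3 differ in the five-membered heterocycle as well, and no measurement shown here accounts for this outcome.

As far as these compounds go, what remains open is whether a group other than chloro at this same place, such as an amine, a carboxylic acid or a methoxy group, would produce a step beyond the scatter in this assay. From the compounds shown here alone, it is also open whether chloro would read the same way on the phenyl-bearing background of compound 3, where the pairing with compound 1 cannot settle the matter.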